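A few compounds are considered here, and "the series" means these few. Any claim that something is new, unique, unknown or untested is made for them only; others in the source may bear on it.

Compound 1 `O=c1c(O)c(-c2ccccc2)oc2cc(OCc3ccccc3Br)cc(O)c12`: in an ADME assay on Huh-5-2 cells (Homo sapiens) for cytotoxicity, read by WST assay, with a stated time of 3 days (on this read-out lower numbers stand for higher toxicity in this test and higher numbers for lower toxicity in this test), compound 1 gives only a limit, > 100000 nM.
Compound 2 `N#Cc1cccc(COc2cc(O)c3c(=O)c(O)c(-c4ccccc4)oc3c2)c1`: in this assay compound 2 gives 72000 nM.
Compound 3 `O=c1c(O)c(-c2ccccc2)oc2cc(OCc3cccc([N+](=O)[O-])c3)cc(O)c12`: in this assay compound 3 gives 76000 nM.

Compound 3 and compound 2 sit within the scatter of each other, as a 1.1-fold higher number from compound 2 to compound 3 (0.02 log units; within the scatter) shows. Compound 1 offers no number, only a limit, (the limit of > 100000 nM in this assay, at which 1 of the 3 values shown sits).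

Compound 4 `O=c1c(O)c(-c2ccccc2)oc2cc(OCc3ccc(Br)cc3)cc(O)c12` is not yet measured. It differs from compound 3 in one place: 4-bromophenyl in place of 3-nitrophenyl on a saturated chain carbon bound to an oxygen on an aromatic ring.

Within the data shown here, two measured steps bear on this change. Going from a bromophenyl to a nitrophenyl group on the same chain carbon gave an at least 1.3-fold lower number from compound 1 to compound 3 (0.11 log units; that floor lies within the scatter), and the cyano analogue gave an at least 1.3-fold lower number from compound 1 to compound 2 (0.14 log units; that floor lies within the scatter). From the compounds shown here alone, both rest on a limit, so their true size is unknown. Among the measured compounds shown here, compound 4 reverses that kind of change, moving back toward a bromine-bearing ring, though with the bromine at a different position on the ring, for which no step is available. The step from compound 3 to compound 4 is therefore expected to be a 1.3-fold higher number from compound 3 to compound 4 (0.12 log units; within the scatter), toward a higher number. Compound 4 is estimated at 100000 nM, within 60000 nM to 200000 nM.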

Compound 4, half-maximal cytotoxic concentration: > 100000 nM
Compound 4: only a limit was reported (the forecaster's own chance of this, stated with the estimate: 50%); the middle value sits exactly at the limit.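

In this assay compound 4 gives only a limit, > 100000 nM. The change to 4-bromophenyl gives an at least 1.3-fold higher number from compound 3 to compound 4 (0.11 log units; that floor lies within the scatter), and measured against the nitrile analogue it gives an at least 1.3-fold higher number from compound 2 to compound 4 (0.14 log units; that floor lies within the scatter); both floors lie within the scatter, so neither step yet shows a real difference. New here is that a second bromophenyl compound, with the bromine elsewhere on the ring, reaches the same limit as compound 1, so the step between these two cannot be read: the limit of > 100000 nM in this assay, at which 2 of the 4 values shown sit.

From the compounds shown here alone, the true numbers behind the two limits remain open, and with them whether the place of the bromine on the ring matters at all. Also open, going by these compounds, is how this read-out would respond to an amine or a carboxylic acid on this ring, or to a longer chain in place of the single chain carbon.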